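The compounds below may be only part of what the source reports. "The series", "measured", "known", "first", "only" and "open" are said of these compounds alone.

Measured so far:
Compound 1, `COCOCCOc1cc(OC)ccc1C[S+]([O-])c1ncccc1C(=O)Nc1ccncc1`, gives < 0.02 h in an ADME assay; a higher number here means that the compound lasts longer, a lower number that the compound disappears faster; this is a limit of the assay, not a number.
Compound 2, `COc1cccc(OC)c1C[S+]([O-])c1ncccc1C(=O)Nc1ccncc1`, gives 0.66 h.
Compound 3, `CCOc1ccc(C[S+]([O-])c2ncccc2C(=O)Nc2ccncc2)c(OCC)c1`, gives < 0.02 h, again a limit rather than a number.

Compound 1 therefore stands at the low end of what is shown, at the limit of < 0.02 h in this assay, at which 2 of the 3 values shown sit, and only compound 2 has a measured number. Compound 4, `COc1ccc(C[S+]([O-])c2ncccc2C(=O)Nc2ccncc2)c(OC)c1`, has not yet been measured. It differs from compound 1 in one place: hydrogen in place of (methoxymethoxy)methyl on a saturated chain carbon bound to an oxygen on an aromatic ring.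

With compound 1 known only as a limit, the step from compound 1 to compound 4 is expected to run upward, of a size beyond the usual scatter, an at least 7.5-fold higher number from compound 1 to compound 4 (0.87 log units; beyond the scatter). Compound 4 is estimated at 0.15 h, expected to fall between 0.02 h and 0.9 h.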

Compound 4, half-life: < 0.02 h
Compound 4 was reported as a limit; the forecaster's own chance of this, stated with the estimate: 30%; middle value at least 7.5-fold (0.87 log units) from the limit.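

Compound 1 and compound 4 are both reported only as limits, so no step can be read between them: the limit of < 0.02 h in this assay, at which 3 of the 4 values shown sit. From the compounds shown here alone, how far putting hydrogen in place of (methoxymethoxy)methyl moves the half-life remains open.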